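A few compounds are considered here, and "the series" means these few. Any claim that something is new, unique, unknown or untested is made for them only; others in the source may bear on it.

Measured in a functional assay, read by spectrophotometry, with a stated time of 30 min; on this read-out lower numbers stand for an effect already at smaller amounts and higher numbers for an effect only at larger amounts of compound:
- compound 1 `Cc1cc([N+](=O)[O-])ccc1NC(=O)/C=C/c1ccc(O)c(O)c1`: 13200 nM
- compound 2 `O=C(/C=C/c1ccc(O)c(O)c1)Nc1ccccc1Nc1ccccc1`: 14700 nM

Compound 1 at 13200 nM and compound 2 at 14700 nM lie within the usual scatter of each other, so compound 1 cannot be ranked against compound 2 on these numbers.

Compound 3 `O=C(/C=C/c1ccc(O)c(O)c1)Nc1ccc([N+](=O)[O-])cc1` is not yet measured. It differs from compound 1 as follows: hydrogen in place of methyl on an aromatic carbon. This is hydrogen in place of methyl on an aromatic carbon, and the nitro group stays.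

For the measured compounds named here, no measured pair shows the effect of this exchange. The expectation in this assay therefore starts from compound 1 at 13200 nM, with no step beyond the scatter and no favoured direction. The expected change is a 1.0-fold lower number from compound 1 to compound 3 (0.01 log units; within the scatter). For compound 3 the estimated value is 13000 nM, with an expected range of 6000 nM to 28000 nM.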

Compound 3, half-maximal effective concentration: 7210 nM
Compound 3: the middle estimate sits 1.8-fold (0.26 log units) above what was measured; low and high end bracket the measured number.
By their numbers in this assay, from the lowest: compounds 3, 1 and 2 (each within the scatter of the next, the first and the last beyond it).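

For the compounds shown here, this is the first pair that differs in one place, and in this assay hydrogen in place of methyl on an aromatic carbon, ortho to a large group and meta to a nitro group, gives a 1.8-fold lower number from compound 1 to compound 3 (0.26 log units; within the scatter) with the nitro group kept. On this pair, the methyl group at this position has no effect that can be told from the scatter, and compound 1 and compound 3 cannot be ranked against each other. Nothing at hand bears on the size of this step.

The compounds shown leave open whether a different group at this place, such as an amine, a methoxy group or a carboxylic acid, would give a step beyond the scatter. They also leave open what a nitrile or an amine in place of the nitro group would give on the core of compound 3.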